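Chloro for fluoro on the phenoxy ring: solubility note

A few compounds are considered here, and "the series" means these few. Any claim that something is new, unique, unknown or untested is made for them only; others in the source may bear on it.

Compound 3 `COc1ccc(F)cc1CNCCCNc1ccnc2cc(Oc3ccc(F)cc3)ccc12` is measured in a physicochemical assay for solubility, with a stated time of 18 h, at pH 7.4 (on this read-out lower numbers stand for lower solubility and higher numbers for higher solubility), where compound 3 gives 14500 nM. This stands level with compound 1 `COc1cccc(CNCCCNc2ccnc3cc(Oc4ccc(Cl)cc4)ccc23)c1O`, which in this assay gives 14500 nM; the two differ in more than one place, so only their values are set side by side, and they show no difference at the digits recorded. Among the compounds with values here, compound 2 `COc1ccc(F)cc1CNCCCNc1ccnc2cc(Cc3ccc(C#N)cc3)ccc12` gives 4200 nM in this assay, a lower number; the step of a 3.5-fold higher number from compound 2 to compound 3 (0.54 log units; beyond the scatter) is the only step in the set, and it concerns 4-fluorophenoxy in place of 4-cyanobenzyl, not the change at hand.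

Compound 4 `COc1ccc(F)cc1CNCCCNc1ccnc2cc(Oc3ccc(Cl)cc3)ccc12` differs from compound 3 as follows: chloro in place of fluoro on an aromatic carbon. The exchange sits on an aromatic carbon of a six-membered aromatic ring of carbon only, para to a large group. Within the data shown here, no measured step tracks this exchange on its own. Compound 1, which carries 4-chlorophenoxy, is level with compound 3 on this read-out, but since it differs elsewhere as well, this is only a loose pointer. The step from compound 3 to compound 4 is expected to be a 1.5-fold lower number from compound 3 to compound 4 (0.16 log units; within the scatter), within the scatter. Compound 4 is estimated at 10000 nM, with a range from 4000 nM to 25000 nM.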

Compound 4, solubility: 14500 nM
For compound 4 the middle estimate is 1.5-fold (0.16 log units) below the measured one; low and high end bracket the measured number.
By their numbers in this assay, from the lowest: compound 2; then compounds 1, 3 and 4 (each within the scatter of the next).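

In this assay, within the data shown here, the exchange of 4-fluorophenoxy for 4-chlorophenoxy gives no change at the digits printed from compound 3 to compound 4 (within the scatter), the first direct reading of this exchange. The step for 4-chlorophenoxy in place of 4-cyanobenzyl is a 3.5-fold higher number from compound 2 to compound 4 (0.54 log units; beyond the scatter), and it matches the step for 4-fluorophenoxy, a 3.5-fold higher number from compound 2 to compound 3 (0.54 log units; beyond the scatter), so both halogens give the same reading against that group. The comparison with compound 1 also becomes a single-place step: with 4-chlorophenoxy held fixed, 5-fluoro-2-methoxyphenyl in place of 2-hydroxy-3-methoxyphenyl gives no change at the digits printed from compound 1 to compound 4 (within the scatter), whereas compound 1 and compound 3 could previously only be set side by side.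

No supporting data bear on why these values coincide. Still open, on these data alone, is whether the same reading holds with a different group at this carbon, such as a methoxy group, an amine or a carboxylic acid, and whether chloro and fluoro also read alike when the 5-fluoro-2-methoxyphenyl group is replaced.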